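The source may report more compounds than this note shows. Statements on the series, on what has been measured and on what is new or still open speak of the compounds shown alone.

For the measured compounds named here, compound 3 `O=C(/C=C/c1cn(-c2ccccc2)nc1-c1ccncc1)c1cc[nH]c1` gives 15700 nM in a functional assay on HCT-116 cells (Homo sapiens) for inhibition, read by sulforhodamine B assay, with a stated time of 72 h (a lower number here means a stronger inhibitor, a higher number a weaker inhibitor), and so stands at the top of the three numbers known; compound 1 `O=C(/C=C/c1cn(-c2ccccc2)nc1-c1cccnc1)c1ccccc1` gives 2000 nM and compound 2 `O=C(/C=C/c1cn(-c2ccccc2)nc1-c1ccncc1)c1ccsc1` gives 1100 nM in this assay. Compound 4 `O=C(/C=C/c1cn(-c2ccccc2)nc1-c1ccncc1)c1ccccc1` has not yet been measured in this assay. It differs from compound 3 in one place: phenyl in place of 1H-pyrrol-3-yl on a carbonyl carbon. Going by the values given here, the only measured step at this position is the one from compound 2 to compound 3, where the thiophen-3-yl gave way to the 1H-pyrrol-3-yl ring, and it brought a 14-fold higher number from compound 2 to compound 3 (1.15 log units; beyond the scatter). The change from compound 3 to compound 4 undoes the pyrrole in favour of a carbon-only ring of the same kind as in compound 1, which carries a benzoyl group on the same chain and sits between compound 2 and compound 3 in this assay. The step from compound 3 to compound 4 is therefore expected to be a large move to a lower number, estimated as an 8.7-fold lower number from compound 3 to compound 4 (0.94 log units; beyond the scatter), with compound 2 and compound 1 showing how far it might go. Compound 4 is expected to reach about 1800 nM in this assay, with a likely range from 700 nM to 5000 nM.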

Compound 4, half-maximal inhibitory concentration: 3100 nM
The estimate for compound 4 lay 1.7-fold (0.24 log units) below the measured number; the measured number falls inside the stated range.
By their numbers in this assay, from the lowest: compounds 2, 1 and 4 (each within the scatter of the next, the first and the last beyond it); then compound 3.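

Compound 4 puts a third ring on the same carbonyl carbon in this assay and shows that the pyrrole's high number is not shared by the all-carbon ring: there is a 5.1-fold lower number from compound 3 to compound 4 (0.70 log units; beyond the scatter) and yet also a 2.8-fold higher number from compound 2 to compound 4 (0.45 log units; beyond the scatter) in the same assay, so phenyl does not match thiophen-3-yl either. The three rings at this position therefore give numbers that all lie beyond the scatter of one another, with thiophen-3-yl lowest, phenyl in the middle and 1H-pyrrol-3-yl highest, an order that rests on these three compounds alone. In a second place, the pair also gives a 1.6-fold higher number from compound 1 to compound 4 (0.19 log units; within the scatter) in this assay and so, with a benzoyl group on the chain, does not separate pyridin-4-yl from pyridin-3-yl.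

From the compounds shown here alone, whether a furan-3-yl ring, a saturated piperidine ring or a phenyl ring carrying an amine or a carboxylic acid on the same carbonyl carbon would fall within this span stays open, as does whether the order of the rings holds when pyridin-3-yl replaces pyridin-4-yl. Nothing measured here speaks to why the rings fall in this order.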